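The source may hold more compounds than are shown below. What is called first, only, known or untested is meant among the compounds shown, and "the series" means these compounds.

Measured compounds:
compound 1 `CC(C)S(=O)(=O)N1CCN(c2cnn(-c3cc(F)cc(F)c3)c(=O)c2OC2CCC(F)C2)CC1`: 2100 ng.h/mL
compound 2 `CC(C)S(=O)(=O)N1CCN(c2cnn(-c3cc(F)cc(F)c3)c(=O)c2OC2CCC(F)(F)C2)CC1`: 440 ng.h/mL
compound 3 `CC(C)S(=O)(=O)N1CCN(c2cnn(-c3cccc(Cl)c3)c(=O)c2OC2CCCC2)CC1`: 490 ng.h/mL

These three were run in an ADME assay on the whole organism for pharmacokinetics, with Rattus norvegicus as the target, with a stated time of 6 h, at a dose of 10 mg/kg by the oral route; a lower number here means less compound in the circulation, a higher number more compound in the circulation at the dose given. Going by the values given here, compound 2 gives the lowest of the three numbers, but its gap to compound 3 lies within the usual scatter, so the two cannot be told apart; only the step of a 4.8-fold lower number from compound 1 to compound 2 (0.68 log units; beyond the scatter) is beyond the scatter, and that step came from fluoro in place of hydrogen on a saturated ring carbon.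

Compound 4 `CC(C)S(=O)(=O)N1CCN(c2cnn(-c3cccc(F)c3)c(=O)c2OC2CCC(F)(F)C2)CC1` has not yet been measured. It differs from compound 2 in one place: hydrogen in place of fluoro on an aromatic carbon. Among the compounds with values here, no measured step touches this place; the only step known is the one on the saturated ring, and compounds 2 and 3 differ in more than one place at once, so their two values alone tell nothing about removing an aromatic fluoro. With no guide in the data, a step of a 1.0-fold higher number from compound 2 to compound 4 (0.01 log units; within the scatter) within the scatter is expected. Compound 4 is therefore expected to give about 450 ng.h/mL, with a range from 180 ng.h/mL to 1100 ng.h/mL.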

Compound 4, area under the concentration-time curve: 470 ng.h/mL
Compound 4: the middle estimate sits 1.0-fold (0.02 log units) below what was measured; the measured number falls inside the stated range.
By their numbers in this assay, from the lowest: compounds 2, 4 and 3 (each within the scatter of the next); then compound 1.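

Going by these compounds alone, removing one fluoro from the aromatic ring, 3,5-difluorophenyl to 3-fluorophenyl, gives a 1.1-fold higher number from compound 2 to compound 4 (0.03 log units; within the scatter), so this is the first measured change on that ring, and this assay cannot tell the two compounds apart. Within the data shown here, the one measured step on the saturated ring, a 4.8-fold lower number from compound 1 to compound 2 (0.68 log units; beyond the scatter), lies beyond the scatter, so with two fluoro groups kept on the saturated ring, this aromatic fluoro can be replaced by hydrogen without a readable change in circulating compound. Nothing available here explains why the swap has so little effect.

This single pair leaves open whether the same swap would stay as quiet with only one fluoro on the saturated ring, as in compound 1. It also leaves open what a larger group on this aromatic carbon, such as methoxy, a nitrile or an amine, would do.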